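The source may report more compounds than this note shows. Statements on the series, on what has been measured and on what is new or still open speak of the compounds shown alone.

Among the compounds with values here, compound 2 `Cc1cc(C)c2cc(C#N)c(NCCNC(=O)c3cnccn3)nc2c1` gives 6700 nM in an in vitro assay on FRT cells with Cystic fibrosis transmembrane conductance regulator variant F508del (Homo sapiens) as the target, read by fluorescence, with a stated time of 24 h, at 37 degrees C, in the presence of a further agent that is not named here (on this read-out higher numbers stand for an effect only at larger amounts of compound and lower numbers for an effect already at smaller amounts), the highest of the two numbers measured so far. Within the data shown here, compound 1 `Cc1cc(C)c2cc(C#N)c(NCCNC(=O)c3cccnc3)nc2c1` gives 2700 nM; the single measured step, a 2.5-fold higher number from compound 1 to compound 2 (0.39 log units; beyond the scatter), shows that the aromatic ring on the carbonyl carbon moves the number beyond the scatter. Compound 3 `COc1ccc(C(=O)NCCNc2nc3cc(C)cc(C)c3cc2C#N)nc1` differs from compound 2 by 5-methoxypyridin-2-yl in place of pyrazin-2-yl on a carbonyl carbon. That one step bears on it only partly, since no measured ring carries a methoxy group. Compound 3 is expected to give 3000 nM (range 1200 nM to 7500 nM). The expected step is a 2.2-fold lower number from compound 2 to compound 3 (0.35 log units; beyond the scatter), toward a lower number, because compound 1 with pyridin-3-yl gave 2700 nM.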

Compound 3, half-maximal effective concentration: 2700 nM
Compound 3: middle estimate off by 1.1-fold (0.05 log units), on the high side; low and high end bracket the measured number.
By their numbers in this assay, from the lowest: compounds 1 and 3 (each within the scatter of the next); then compound 2.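

On the carbonyl carbon, 5-methoxypyridin-2-yl in place of pyrazin-2-yl gives a 2.5-fold lower number from compound 2 to compound 3 (0.39 log units; beyond the scatter), while in place of pyridin-3-yl it gives no change at the digits printed from compound 1 to compound 3 (within the scatter). In this assay a ring carrying a methoxy group therefore fits this position, and compound 3 stands level with compound 1, with only compound 2 apart from them. No measurement offered here explains these steps.

From the compounds shown here alone, how a ring carrying an amine or a carboxylic acid in place of the methoxy group would read remains open. Going by these compounds, the share of the methoxy group itself in the step also remains open.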